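Nitro for bromo on the shared core

This account rests on a few compounds, and the source may have more. Where it says the series, first, only, none or still open, it means among the compounds named here.

In a functional assay on MCF7 cells (Homo sapiens) for cytotoxicity, read by MTT assay, with a stated time of 48 h (a higher number here means a weaker inhibitor, a lower number a stronger inhibitor), the measured compounds stand as follows:

Compound 1, `CCn1c(/C=C2/C(=O)Nc3ccccc32)nc2ccccc21`: "not determined" (no result reported)
Compound 2, `CCn1c(/C=C2/C(=O)Nc3ccc(C)cc32)nc2ccccc21`: > 50000 nM
Compound 3, `CCn1c(/C=C2/C(=O)Nc3ccc(Br)cc32)nc2ccccc21`: "not determined" (no result reported)

Compound 3 has no number in this assay. Of the other two entries, compound 2 sits at a limit of the assay, (the limit of > 50000 nM in this assay, at which 1 of the 3 values shown sits), and compound 1 has no result at all. Compound 4, `CCn1c(/C=C2/C(=O)Nc3ccc([N+](=O)[O-])cc32)nc2ccccc21`, differs from compound 3 by nitro in place of bromo on an aromatic carbon. Going by the values given here, with no measured step in this set, no direction for the change can be drawn from the data, and nothing says the step should exceed the usual scatter. Given that compound 2 gives only a limit in this assay, compound 4 is expected to be weak as well, estimated at 40000 nM with a range from 8000 nM to 150000 nM.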

Compound 4, half-maximal inhibitory concentration: > 50000 nM
Compound 4: no number, only a limit (the forecaster's own chance of this, stated with the estimate: 55%); middle value at least 1.2-fold (0.09 log units) from the limit.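

No step can be read from compound 2 to compound 4, because both give only a limit, not a number: the limit of > 50000 nM in this assay, at which 2 of the 4 values shown sit.

The compounds shown leave open whether nitro, methyl or bromo on the shared core differ at all in this cytotoxicity read-out.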